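Butyl to isobutyl on the shared core

The compounds below may be only part of what the source reports. "The series", "measured", "known", "first", "only" and "open" are said of these compounds alone.

- compound 1 `CCCOC(=O)c1cc(N2C(=O)C3=C(CCCC3)C2=O)ccc1Cl`: 1120 nM
- compound 2 `CCCCOC(=O)c1cc(N2C(=O)C3=C(CCCC3)C2=O)ccc1Cl`: 6310 nM

In a functional assay on the whole organism for inhibition, with Scenedesmus acutus as the target (a higher number here means a weaker inhibitor, a lower number a stronger inhibitor), compound 2 has the higher of the two numbers, 6310 nM. Compound 3 `CC(C)COC(=O)c1cc(N2C(=O)C3=C(CCCC3)C2=O)ccc1Cl` has the same atoms joined differently: isopropyl in place of propyl on a saturated chain carbon bound to an oxygen next to a carbonyl group, read one bond further out as butyl to isobutyl. Going by the values given here, the only measured step that bears on this is a 5.6-fold higher number from compound 1 to compound 2 (0.75 log units; beyond the scatter), which is modest and comes from methyl in place of hydrogen on the chain. No branched chain has been measured, so this guide is weak. A smaller move towards a lower number is expected. The expected step is a 2.3-fold lower number from compound 2 to compound 3 (0.35 log units; beyond the scatter). Compound 3 is estimated at 2800 nM, with an expected range of 900 nM to 8000 nM.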

Compound 3, half-maximal inhibitory concentration: 977 nM
Estimate against measurement, compound 3: 2.9-fold (0.46 log units) above; the measured number falls inside the stated range.
By their numbers in this assay, from the lowest: compounds 3 and 1 (each within the scatter of the next); then compound 2.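

In this assay, moving from butyl to isobutyl gives a 6.5-fold lower number from compound 2 to compound 3 (0.81 log units; beyond the scatter), so at this position the same atoms joined differently change the number as much as the added methyl did. Against the propyl ester, the isobutyl ester gives a 1.1-fold lower number from compound 1 to compound 3 (0.06 log units; within the scatter), so this added methyl, unlike the one in the butyl chain, leaves the number unmoved. Nothing measured here accounts for the gap between the butyl and isobutyl esters.

Going by these compounds, whether a tert-butyl ester or a longer chain such as pentyl tracks compound 2 or compound 3 remains open. So does the outcome of replacing the ester with an amide.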